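Replacing an Open-Chain Amine with an Ethylpiperazine Ring

The source may hold more compounds than are shown below. What is called first, only, known or untested is meant among the compounds shown, and "the series" means these compounds.

Compound 1 `CCN1CCC(CC(=O)NC2(c3ccc(Cl)c(Cl)c3)C(=O)Nc3cc(Cl)cc(Cl)c32)CC1`: 1 nM
Compound 2 `CN(C)C1CCN(CC(=O)NC2(c3ccc(Cl)c(Cl)c3)C(=O)Nc3cc(Cl)cc(Cl)c32)CC1`: 239 nM
Compound 3 `CN(C)CCN(C)CC(=O)NC1(c2ccc(Cl)cc2)C(=O)Nc2cc(Cl)c(Cl)cc21`: > 10000 nM

In an in vitro functional assay on CHO-CREluc cells for antagonist activity at growth hormone secretagogue receptor type 1 (Homo sapiens), read by a luciferase reporter, with a stated time of 4 h (a higher number here means a weaker inhibitor, a lower number a stronger inhibitor), compound 3 reaches only a limit, (the limit of > 10000 nM in this assay, at which 1 of the 3 values shown sits), and has no number of its own. Compound 4 `CCN1CCN(CC(=O)NC2(c3ccc(Cl)cc3)C(=O)Nc3cc(Cl)c(Cl)cc32)CC1` differs from it in one place: 4-ethylpiperazin-1-yl in place of (2-(dimethylamino)ethyl)(methyl)amino on a saturated chain carbon bound to a carbonyl carbon. Among the compounds with values here, the only measured step concerns the same place, a 240-fold higher number from compound 1 to compound 2 (2.38 log units; beyond the scatter), and shows that a change in the amine there can move the read-out a great deal. Both compounds with a cyclic amine, compound 1 at 1 nM and compound 2 at 239 nM, give numbers rather than a limit. Compound 4 is therefore expected to give a number, 2000 nM, with a range from 300 nM to 10000 nM, meaning an estimated step of an at least 5.0-fold lower number from compound 3 to compound 4 (0.69 log units; beyond the scatter) towards a stronger inhibitor.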

Compound 4, half-maximal inhibitory concentration: 110 nM
Beside the measured number, compound 4's estimate is 18-fold (1.26 log units) above it; the measured number lies below the stated range.
By their numbers in this assay, from the lowest: compound 1; then compound 4; then compound 2. At a limit, above all of these: compound 3.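

On a saturated chain carbon bound to a carbonyl carbon, 4-ethylpiperazin-1-yl in place of (2-(dimethylamino)ethyl)(methyl)amino gives an at least 90-fold lower number from compound 3 to compound 4 (1.95 log units; beyond the scatter) in this assay. Going by these compounds, compound 3 has only a limit, so the full size of this step stays unknown: the limit of > 10000 nM in this assay, at which 1 of the 4 values shown sits. Whereas the earlier step compared two cyclic amines, this one goes from an open-chain amine to a ring and takes the read-out from a limit to a number.

The compounds shown leave open whether a morpholine or a piperazine carrying methyl instead of ethyl would serve equally well here. They also leave open whether this exchange would have a similar effect on the core of compound 1.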